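A few compounds are considered here, and "the series" means these few. Any claim that something is new, unique, unknown or untested is made for them only; others in the source may bear on it.

Compound 1 `Cc1ccc2c(c1)-c1cnc(n1C)OCCCCCCCCO2` and compound 2 `COc1ccc2c(c1)-c1cnc(n1C)OCCCCCCCCO2` share one core. In a functional assay on A549 cells (Homo sapiens) for inhibition, read by colorimetric assay and MTT assay, with a stated time of 72 h (on this read-out higher numbers stand for weaker inhibition and lower numbers for stronger inhibition), compound 1 gives 41000 nM and compound 2 gives 40000 nM, so the step is a 1.0-fold lower number from compound 1 to compound 2 (0.01 log units; within the scatter), the change being (methoxy in place of methyl on an aromatic carbon). Compound 3 `C=CCCCCOc1ccc(C)cc1-c1cnc(OCCC=C)n1C` has a different core; the difference between the two cores is not broken down here. In this assay compound 3 gives 59000 nM. Compound 4 `C=CCCCCOc1ccc(OC)cc1-c1cnc(OCCC=C)n1C` is not yet measured; it differs from compound 3 by methoxy in place of methyl on an aromatic carbon, the same kind of change as in the first pair, though the place differs: in compound 1 the aromatic carbon is part of a fused or bridged system of three rings, meta to a fused ring and para to a fused ring, whereas in compound 3 it is meta to a large group and para to a (hex-5-en-1-yl)oxy group. The expected step in this assay is a 1.1-fold lower number from compound 3 to compound 4 (0.03 log units; within the scatter), resting on the earlier step of a 1.0-fold lower number from compound 1 to compound 2 (0.01 log units; within the scatter) lying within the scatter. The estimate for compound 4 in this assay is 55000 nM, between 25000 nM and 120000 nM.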

Compound 4, half-maximal inhibitory concentration: 43000 nM
Compound 4: the middle estimate sits 1.3-fold (0.11 log units) above what was measured, and the stated range covers the measured number.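

On the core of compound 3, methoxy in place of methyl on an aromatic carbon gives a 1.4-fold lower number from compound 3 to compound 4 (0.14 log units; within the scatter) in this assay. Set beside the same change on the core of compound 1, the step does not differ: the same change on two cores in this assay, a 1.0-fold lower number (0.01 log units; within the scatter) from compound 1 to compound 2 and a 1.4-fold lower number (0.14 log units; within the scatter) from compound 3 to compound 4, 1.3-fold (0.13 log units) apart, within the scatter of two such steps. This shows that the change stays within the scatter on both cores in this assay, but two pairs give no rule for other cores, and any true difference between the steps smaller than the scatter cannot be seen.

Still open, going by these compounds, is whether an amine or a carboxylic acid on this aromatic carbon would give a step beyond the scatter. Also open, on these data alone, is whether a longer chain in place of the (hex-5-en-1-yl)oxy group would do so.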